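This account rests on a few compounds, and the source may have more. Where it says the series, first, only, none or still open, it means among the compounds named here.

In a functional assay on BT-549 cells (Homo sapiens) for cytotoxicity, read by sulforhodamine B assay, with a stated time of 48 h (on this read-out lower numbers stand for higher toxicity in this test and higher numbers for lower toxicity in this test), compound 1 `Nc1nc(Cl)c2ncn(Cc3ccccc3CCl)c2n1` gives 57500 nM. Compound 2 `Nc1nc(Cl)c2ncn(Cc3cccc(CCl)c3)c2n1` gives 58900 nM in this assay. The two numbers lie within the scatter of repeated measurements of each other, so compound 1 is not separated from compound 2 in this test; both show toxicity only at a fairly high concentration.

Compound 3 `ClCc1ccccc1Cn1cnc2c(Cl)ncnc21` has not yet been measured. It differs from compound 1 in one place: hydrogen in place of amino on an aromatic carbon. The amino group is gone and a hydrogen atom sits on that aromatic carbon of the six-membered aromatic ring with 2 nitrogen. Among the measured compounds shown here, no pair of measured compounds shows a change of this kind, so nothing measured tells how large the step should be. With both measured compounds sitting at high concentration in this assay, a single small change is expected to move the number little, if at all beyond the scatter, perhaps slightly toward lower toxicity. The expected step from compound 1 to compound 3 is a 1.2-fold higher number from compound 1 to compound 3 (0.09 log units; within the scatter). For compound 3 the estimate in this assay is 70000 nM, within a range from 25000 nM to 200000 nM.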

Compound 3, concentration lethal to 50% of the cells: 20000 nM
Compound 3: the middle estimate sits 3.5-fold (0.54 log units) above what was measured; measured number outside the range, below it.
By their numbers in this assay, from the lowest: compound 3; then compounds 1 and 2 (each within the scatter of the next).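

Among the compounds shown here, replacing the amino group with hydrogen on the aromatic carbon between two ring nitrogen atoms gives the first step in this set that can be told apart from the scatter: in this assay the change gives a 2.9-fold lower number from compound 1 to compound 3 (0.46 log units; beyond the scatter). Since lower numbers stand for higher toxicity in this test, the amino group is not needed for the toxicity seen here, and the compound with hydrogen at this position is the more toxic of the pair, although the step is modest and rests on this single pair. Nothing available explains why this change moves the number.

The compounds shown leave open how other groups at this position, such as a methyl group, a methylamino group or a hydroxyl group, would compare with amino and hydrogen. They also leave open whether the same exchange would give a similar step on compound 2, where the chloromethyl group sits at a different place on the benzene ring, so the step cannot yet be called a general pattern.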